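Swapping the Group on a Saturated Ring Carbon

The source may report more compounds than this note shows. Statements on the series, on what has been measured and on what is new or still open speak of the compounds shown alone.

In a functional assay on Ehrlich cells (Mus musculus) for antiproliferative activity, read by trypan blue exclusion, with a stated time of 2 h (on this read-out lower numbers stand for stronger inhibition and higher numbers for weaker inhibition), compound 1 (`COc1cc(CC2C(C#N)=C(N)N(c3ccc(S(N)(=O)=O)cc3)C3=C2C(=O)CCC3)ccc1O`) gives 25 ug/mL and compound 2 (`COc1ccc2ccccc2c1C1C(C#N)=C(N)N(c2ccc(S(N)(=O)=O)cc2)C2=C1C(=O)CCC2`) gives 12.5 ug/mL. These two numbers are all that has been measured so far, and they lie within the scatter of each other, so compound 2 cannot be set apart from compound 1. The next compound, compound 3 (`Cc1ccoc1C1C(C#N)=C(N)N(c2ccc(S(N)(=O)=O)cc2)C2=C1C(=O)CCC2`), shares the core of compound 2 but has not yet been measured. The structural difference is 3-methylfuran-2-yl in place of 2-methoxynaphthalen-1-yl on a saturated ring carbon. In compound 3, 3-methylfuran-2-yl stands in place of 2-methoxynaphthalen-1-yl on a saturated ring carbon.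

Among the compounds with values here, the only measured step, a 2.0-fold lower number from compound 1 to compound 2 (0.30 log units; within the scatter), also exchanges the group on that carbon. It is a single step, and neither measured compound carries a five-membered aromatic ring, so the evidence is thin. On that basis, no change beyond the scatter is expected in this assay. The expected step is a 1.4-fold higher number from compound 2 to compound 3 (0.16 log units; within the scatter). For compound 3 the estimated value is 18 ug/mL, with an expected range of 7 ug/mL to 45 ug/mL.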

Compound 3, half-maximal inhibitory concentration: > 100 ug/mL
Compound 3 gave a limit, no number; the forecaster's own chance of this, stated with the estimate: 10%; middle value at least 5.5-fold (0.74 log units) away from the limit.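

Compound 3 gives a limit of the assay rather than a number in this assay: the limit of > 100 ug/mL in this assay, at which 1 of the 3 values shown sits.

Within the data shown here, the earlier exchange at this saturated ring carbon, a 2.0-fold lower number from compound 1 to compound 2 (0.30 log units; within the scatter), could not set its two compounds apart, whereas 3-methylfuran-2-yl brings the first steps beyond the scatter at this position: an at least 8.0-fold higher number from compound 2 to compound 3 (0.90 log units; beyond the scatter) and an at least 4.0-fold higher number from compound 1 to compound 3 (0.60 log units; beyond the scatter). The group on this carbon is therefore not interchangeable in this assay, since a single exchange on the shared core is enough to move the read-out past the scatter, and here the entering group is the only one of the three with a five-membered aromatic ring.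

On these data alone, whether a furan-2-yl without the methyl group, or a plain phenyl, on this carbon would stay within the scatter of compound 2 remains open, so the change cannot be tied to the five-membered ring, the methyl group or the size of the group. Equally open is whether an amine or a carboxylic acid on the group at this carbon would shift the read-out, and the steps shown do not tell why it moved.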